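The source may report more compounds than this note shows. Statements on the series, on what has been measured and on what is new or still open speak of the compounds shown alone.

In a functional assay on A-375 cells (Homo sapiens) for antiproliferative activity, read by CCK-8 assay, with a stated time of 72 h (on this read-out higher numbers stand for weaker inhibition and lower numbers for stronger inhibition), compound 1 (`Nc1ccccc1NC(=O)/C=C/c1ccc(CSc2ccc(F)cc2)cc1`) gives 3670 nM and compound 2 (`COC(=O)c1ccccc1SCc1ccc(C(=O)Nc2ccccc2N)cc1`) gives 3610 nM; these two values lie within the scatter of each other, so neither compound separates from the other. Compound 3 (`CC(C)(C)c1ccc(SCc2ccc(/C=C/C(=O)Nc3ccccc3N)cc2)cc1`) keeps the core of compound 1 and carries tert-butyl in place of fluoro on an aromatic carbon, para to a large group (tert-butyl in place of fluoro on an aromatic carbon). Within the data shown here, no measured pair covers this change, so only a small step without a firm direction is expected in this assay, the estimated move a 1.2-fold lower number from compound 1 to compound 3 (0.09 log units; within the scatter) staying inside the scatter. For compound 3 the expected value is 3000 nM (estimated range 1000 nM to 9000 nM).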

Compound 3, half-maximal inhibitory concentration: 1550 nM
For compound 3 the middle estimate is 1.9-fold (0.29 log units) above the measured one, within the range that was stated.
By their numbers in this assay, from the lowest: compound 3; then compounds 2 and 1 (each within the scatter of the next).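

Para to a large group on the aromatic ring, the change from 4-fluorophenyl to 4-(tert-butyl)phenyl gives the first step in the series that clears the scatter in this assay: a 2.4-fold lower number from compound 1 to compound 3 (0.37 log units; beyond the scatter) is a modest gain. This position therefore accepts tert-butyl, with four heavy atoms in place of the single fluorine, without loss of antiproliferative activity. Nothing available explains this step.

From the compounds shown here alone, whether methoxy, an amine or a carboxylic acid at this position would move the number in the same direction remains open. Also open, going by these compounds, is whether tert-butyl would give a similar step on the core of compound 2.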